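The source may hold more compounds than are shown below. What is called first, only, known or untested is meant among the compounds shown, and "the series" means these compounds.

Compound 1 `O=C(CN(C(=O)c1ccc(-c2ccccn2)cc1)C1CCCOC1)Nc1cc(F)cc(F)c1` gives 2 mL.min-1.g-1
Compound 2 `COCC(C)N(CC(=O)Nc1cc(F)cc(F)c1)C(=O)c1ccc(-c2ccccn2)cc1` gives 4.2 mL.min-1.g-1

Going by the values given here, in an in vitro ADME assay on microsomes (Rattus norvegicus) for metabolic stability (a lower number here means slower removal, a higher number faster removal of the compound), compound 2 gives 4.2 mL.min-1.g-1 as the higher of the two numbers so far. Compound 3 `CCC(COC)N(CC(=O)Nc1cc(F)cc(F)c1)C(=O)c1ccc(-c2ccccn2)cc1` has not yet been measured and differs from compound 2 by methyl in place of hydrogen on a saturated chain carbon, two bonds along the chain from an amide-type nitrogen in this one place. Read one bond further out, this is methyl to ethyl, which turns 1-(methoxymethyl)ethyl into 1-(methoxymethyl)propyl. Among the compounds with values here, only one measured step bears on this change, and it is a 2.1-fold higher number from compound 1 to compound 2 (0.32 log units; beyond the scatter) with 1-(methoxymethyl)ethyl in place of oxan-3-yl on an amide-type nitrogen. That step is modest, though beyond the scatter, and it swaps a whole group rather than adding a methyl, so it offers only a rough guide to size. Within the data shown here, no measured pair shows the methyl change itself. A small rise in this assay is therefore expected, probably not beyond the scatter. The estimated step is a 1.3-fold higher number from compound 2 to compound 3 (0.12 log units; within the scatter) with wide uncertainty in either direction. For compound 3 the estimate is 5.5 mL.min-1.g-1 as the expected value, with an expected range from 2.5 mL.min-1.g-1 to 12 mL.min-1.g-1 for repeat measurements.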

Compound 3, intrinsic clearance in microsomes in the Rattus norvegicus assay: 6.7 mL.min-1.g-1
Estimate against measurement, compound 3: 1.2-fold (0.09 log units) below; the range from low to high includes it.
By their numbers in the Rattus norvegicus assay, from the lowest: compound 1; then compounds 2 and 3 (each within the scatter of the next).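

In the Rattus norvegicus assay the methyl to ethyl change can now be read directly, as methyl in place of hydrogen on a saturated chain carbon, two bonds along the chain from an amide-type nitrogen: compound 2 gives 4.2 mL.min-1.g-1 and compound 3 gives 6.7 mL.min-1.g-1, which is a 1.6-fold higher number from compound 2 to compound 3 (0.20 log units; within the scatter) and so does not separate the two compounds. In the Rattus norvegicus assay oxan-3-yl and 1-(methoxymethyl)propyl, by contrast, lie clearly apart, with a 3.4-fold higher number from compound 1 to compound 3 (0.53 log units; beyond the scatter), so both open-chain groups shown now stand beyond the scatter of compound 1. In a physicochemical assay for lipophilicity (on this read-out higher numbers stand for higher lipophilicity and lower numbers for lower lipophilicity), compound 2 gives 3 and compound 3 gives 3.3, and the same change gives a number 0.30 log units higher from compound 2 to compound 3 (within the scatter), so neither read-out resolves compound 2 from compound 3, and nothing shown accounts for these readings.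

The compounds shown leave open whether a longer chain such as butyl, or an amine or a carboxylic acid, on this saturated chain carbon would give a step beyond the scatter in the Rattus norvegicus assay. As far as these compounds go, it also remains open whether the lower number of compound 1 is particular to oxan-3-yl or would also hold for another ring, such as oxolan-3-yl.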